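Loss of a Chloro Group Across Two Related Cores

The source may hold more compounds than are shown below. What is called first, only, known or untested is meant among the compounds shown, and "the series" means these compounds.

The study compares four compounds built on two closely related cores. Compound 1 `ClCc1ccccc1Cn1cnc2c(Cl)nc(Cl)nc21` and compound 2 `ClCc1ccccc1Cn1cnc2c(Cl)ncnc21` share one core, while compound 3 `ClCc1ccc(Cn2cnc3nc(Cl)nc(Cl)c32)cc1` and compound 4 `ClCc1ccc(Cn2cnc3ncnc(Cl)c32)cc1` share the other; the difference between the two cores is not broken down here.

Activity was measured in a functional assay on T47D cells (Homo sapiens) for cytotoxicity, read by sulforhodamine B assay, with a stated time of 48 h; a higher number here means a weaker inhibitor of growth, a lower number a stronger inhibitor of growth. Compound 1 gives 5490 nM. For the measured compounds named here, compound 2 gives 61700 nM, and the single change that separates the two is hydrogen in place of chloro on an aromatic carbon. This change produced an 11-fold higher number from compound 1 to compound 2 (1.05 log units; beyond the scatter).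

In this assay compound 3 gives 46800 nM, close to the value of compound 2 and well apart from that of compound 1. Compound 4 has not yet been measured. It differs from compound 3 by hydrogen in place of chloro on an aromatic carbon, which is the same change, at the same kind of place, as that from compound 1 to compound 2.

On the strength of that one observed step, compound 4 is expected to show a 7.5-fold higher number from compound 3 to compound 4 (0.87 log units; beyond the scatter), a step estimated from the size of an 11-fold higher number from compound 1 to compound 2 (1.05 log units; beyond the scatter) applied to the value of compound 3. Because compound 3 already starts at 46800 nM, the expected value for compound 4 is 350000 nM, with a plausible range from 100000 nM to 1000000 nM; a number this high may exceed what the assay can report.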

Compound 4, concentration for total growth inhibition: 2880 nM
The estimate for compound 4 lay 120-fold (2.08 log units) above the measured number; the whole stated range lies above it.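

In this assay, hydrogen in place of chloro on an aromatic carbon gave a 16-fold lower number from compound 3 to compound 4 (1.21 log units; beyond the scatter), so the same change weakened growth inhibition on one core and strengthened it on the other: the same change on two cores in this assay, an 11-fold higher number (1.05 log units; beyond the scatter) from compound 1 to compound 2 and a 16-fold lower number (1.21 log units; beyond the scatter) from compound 3 to compound 4, 180-fold (2.26 log units) apart, beyond the scatter of two such steps. In this series, therefore, neither the direction nor the size of the step seen on the core of compound 1 carries over to the core of compound 3, and a step read on one of these cores is no safe guide to the step on the other. This does not show why the two steps part ways, and with a single pair on each core it cannot tell whether either direction would hold for other compounds built on the same cores.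

The compounds shown leave open what an amine or a methoxy group would do in place of the chloro group at this same spot on each core, and whether such replacements would also split between the two cores. They also leave open whether a longer chain in place of the chloromethyl group would alter the contrast between the two steps.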